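The source may report more compounds than this note shows. Statements on the series, on what has been measured and on what is new or still open speak of the compounds shown alone.

Measured in a functional assay on cells (Neuron, Rattus norvegicus) for inhibition, read by LDH release, with a stated time of 24 h; on this read-out lower numbers stand for stronger inhibition and higher numbers for weaker inhibition:
- compound 1 `C=CCN(c1ccc(C)cc1)c1nc(=O)c2cccnc2s1`: 9000 nM
- compound 2 `CN(c1ccc(C(F)(F)F)cc1)c1nc(=O)c2cccnc2s1`: 2000 nM

Of these two numbers, compound 2, at 2000 nM, holds the lower, which stands for the stronger inhibition, and its gap to compound 1 lies beyond the usual scatter. Compound 3 `Cc1ccc(N(C)c2nc(=O)c3cccnc3s2)cc1` is compound 2 with methyl in place of trifluoromethyl on an aromatic carbon, para to a large group: methyl in place of trifluoromethyl on an aromatic carbon. Within the data shown here, no measured pair shows this change alone, so its size remains open. Compound 1 also carries methyl on an aromatic carbon and gives 9000 nM, so a modest rise in the number, toward weaker inhibition, is expected in this assay, near the edge of the scatter. The expected step is a 2.0-fold higher number from compound 2 to compound 3 (0.30 log units; within the scatter). For compound 3 the estimated value is 4000 nM, with an expected range from 1500 nM to 11000 nM.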

Compound 3, half-maximal inhibitory concentration: 10000 nM
For compound 3 the middle estimate is 2.5-fold (0.40 log units) below the measured one, within the range that was stated.
By their numbers in this assay, from the lowest: compound 2; then compounds 1 and 3 (each within the scatter of the next).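

With only the shared core and the nitrogen's methyl held constant, methyl in place of trifluoromethyl on this aromatic carbon, para to a large group, gives a 5.0-fold higher number from compound 2 to compound 3 (0.70 log units; beyond the scatter) in this assay, which isolates this change as one that moves the number toward weaker inhibition. Hydrogen in place of vinyl on the saturated chain carbon bound to the nitrogen gives a 1.1-fold higher number from compound 1 to compound 3 (0.05 log units; within the scatter) in this assay, so that change leaves no difference that can be told from the scatter. Nothing available explains the size of either step.

The compounds shown leave open what a chlorine, a methoxy or a nitrile would give on this aromatic carbon, and so whether the number follows any trend across groups there. They also leave open whether trifluoromethyl would give a similar step when carried with the vinyl-bearing chain of compound 1.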